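This account rests on a few compounds, and the source may have more. Where it says the series, first, only, none or still open, it means among the compounds named here.

Compound 1 `CC1C(=O)N(C)c2cnc(Nc3ccc(S(N)(=O)=O)cc3)nc2N1C` gives 313 nM in an assay on Sf9 cells for inhibition of serine/threonine-protein kinase 4 (Homo sapiens), read by luminescence and ADP-Glo, with a stated time of 1 h, in the presence of a further agent that is not named here; on this read-out higher numbers stand for weaker inhibition and lower numbers for stronger inhibition. Within the data shown here, compound 2 `CN1C(=O)C(c2cccc(Cl)c2)N(C)c2nc(Nc3ccc(S(N)(=O)=O)cc3)ncc21` gives 989 nM in this assay, the higher of the two numbers; the change a 3.2-fold higher number from compound 1 to compound 2 (0.50 log units; beyond the scatter) is the only measured comparison available. Compound 3 `CN1C(=O)C(c2ccccc2C(F)(F)F)N(C)c2nc(Nc3ccc(S(N)(=O)=O)cc3)ncc21` has not been measured; it differs from compound 2 by 2-(trifluoromethyl)phenyl in place of 3-chlorophenyl on a saturated ring carbon. Among the measured compounds shown here, no measured step exchanges one aromatic ring for another, so that single step offers only a loose guide. The number for compound 3 is therefore expected to stay near that of compound 2, with the step of a 1.2-fold higher number from compound 2 to compound 3 (0.08 log units; within the scatter) expected to remain within the scatter. The estimate for compound 3 is 1200 nM, ranging from 400 nM to 4000 nM.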

Compound 3, half-maximal inhibitory concentration: 56 nM
The estimate for compound 3 lay 21-fold (1.33 log units) above the measured number; measured number outside the range, below it.
By their numbers in this assay, from the lowest: compound 3; then compound 1; then compound 2.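

An aromatic ring on this saturated ring carbon need not weaken inhibition in this assay: exchanging the ring substituent gives an 18-fold lower number from compound 2 to compound 3 (1.25 log units; beyond the scatter) and replacing methyl with 2-(trifluoromethyl)phenyl gives a 5.6-fold lower number from compound 1 to compound 3 (0.75 log units; beyond the scatter) as the result. The outcome at this position therefore depends strongly on which aromatic group is present, and compound 2 alone did not reveal this. Nothing shown here explains the gain.

Compound 2 and compound 3 differ in both the substituent and its place on the phenyl ring, so these two changes cannot be separated. On these data alone, the effect of an amine or a carboxylic acid on this carbon also remains open.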